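The source may hold more compounds than are shown below. What is called first, only, known or untested is meant among the compounds shown, and "the series" means these compounds.

Measured so far:
compound 1, `Cn1c(Cc2nn(C)c(=O)c3ccccc23)nnc1SCCCCCCCC(=O)Nc1ccc(Br)cc1Br`, 1500 nM
compound 2, `Cn1c(Cc2nn(C)c(=O)c3ccccc23)nnc1SCCCCCCCC(=O)Oc1ccc(Cl)cc1Cl`, 800 nM
compound 3, `COc1ccc(NC(=O)CCCCCCCSc2nnc(Cc3nn(C)c(=O)c4ccccc34)n2C)cc1`, 3900 nM

All three numbers come from an assay on isolated protein (Mus musculus) for inhibition of IL15-IL15 receptor (Homo sapiens), read by resazurin assay, with stated times of 30 min and 2.5 days; on this read-out higher numbers stand for weaker inhibition and lower numbers for stronger inhibition. Compound 3 stands highest of the three, the number rising a 2.6-fold higher number from compound 1 to compound 3 (0.41 log units; beyond the scatter) and a 4.9-fold higher number from compound 2 to compound 3 (0.69 log units; beyond the scatter). Compound 4, `Cn1c(Cc2nn(C)c(=O)c3ccccc23)nnc1SCCCCCCCC(=O)Nc1ccc(F)cc1F`, differs from compound 3 in one place: 2,4-difluorophenyl in place of 4-methoxyphenyl on an amide-type nitrogen. The step that bears most on this is the modest rise seen when a 2,4-dibromophenyl gave way to the 4-methoxyphenyl, from compound 1 to compound 3; the step from compound 2 points the same way, though it also alters the link to the carbonyl. Returning to a 2,4-dihalophenyl, now with fluorine, is therefore expected to lower the number modestly, a 2.0-fold lower number from compound 3 to compound 4 (0.29 log units; within the scatter). Compound 4 is expected to give about 2000 nM in this assay, between 900 nM and 4500 nM.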

Compound 4, half-maximal inhibitory concentration: 2300 nM
The estimate for compound 4 lay 1.2-fold (0.06 log units) below the measured number; the range from low to high includes it.
By their numbers in this assay, from the lowest: compounds 2, 1, 4 and 3 (each within the scatter of the next, the first and the last beyond it).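

With 2,4-difluorophenyl on the amide-type nitrogen, this assay shows no difference beyond the scatter from 4-methoxyphenyl (a 1.7-fold lower number from compound 3 to compound 4 (0.23 log units; within the scatter)) or from 2,4-dibromophenyl (a 1.5-fold higher number from compound 1 to compound 4 (0.19 log units; within the scatter)), so compound 4 sits within the scatter of both, although those two groups differ beyond it. Among these compounds, the one step beyond the scatter (a 2.9-fold higher number from compound 2 to compound 4 (0.46 log units; beyond the scatter)) changes the link to the carbonyl and the halogens together, so their separate shares cannot be read. Nothing available explains these differences.

From the compounds shown here alone, how a (2,4-dichlorophenyl)amino group would compare on the same carbonyl carbon remains open. So does the effect of a plain phenyl ring or a shorter chain.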